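Methylsulfanyl substitution on two nucleoside cores

This account rests on a few compounds, and the source may have more. Where it says the series, first, only, none or still open, it means among the compounds named here.

Measured compounds:
- Compound 1, `Cc1nsc2ncn([C@H]3C[C@H](O)[C@@H](CO)O3)c12`: in a functional assay on KB cells (Homo sapiens) for antiproliferative activity (a higher number here means a weaker inhibitor, a lower number a stronger inhibitor), compound 1 gives only a limit, > 100000 nM.
- Compound 2, `CSc1nc2snc(C)c2n1[C@H]1C[C@H](O)[C@@H](CO)O1`: in this assay compound 2 gives 30000 nM.
- Compound 3, `Cc1nsc2c1ncn2[C@@H]1O[C@H](CO)[C@@H](O)[C@H]1O`: in this assay compound 3 gives 90000 nM.

Compound 1 and compound 2 differ by one change, (methylsulfanyl in place of hydrogen on an aromatic carbon), and this brings an at least 3.3-fold lower number from compound 1 to compound 2 (0.52 log units; beyond the scatter). The size of that step is known only as a lower bound because of the limit of > 100000 nM in this assay, at which 1 of the 3 values shown sits.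

Compound 3 differs from compound 1 in more than one place; the difference between the two cores is not broken down here. In this assay compound 3 gives the highest number of the two numbers in hand, and of the two sits nearer to compound 2.

Compound 4, `CSc1nc2c(C)nsc2n1[C@@H]1O[C@H](CO)[C@@H](O)[C@H]1O`, is not yet measured. It carries the change (methylsulfanyl in place of hydrogen on an aromatic carbon). This is the same kind of change as that from compound 1 to compound 2, but the place is not the same word for word: in compound 2 the ring atom next to the site bears a group of 8 heavy atoms, in compound 4 a group of 9 heavy atoms.

For compound 4 the step from compound 3 is expected to be a 3.6-fold lower number from compound 3 to compound 4 (0.56 log units; beyond the scatter), resting on the step of an at least 3.3-fold lower number from compound 1 to compound 2 (0.52 log units; beyond the scatter), which is only a lower bound. Compound 4 is estimated in this assay at 25000 nM, with a likely range from 8000 nM to 80000 nM.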

Compound 4, half-maximal inhibitory concentration: > 100000 nM
Compound 4: only a limit was reported; the forecaster's own chance of this, stated with the estimate: 5%; middle value at least 4.0-fold (0.60 log units) away from the limit.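

The methylsulfanyl change does not carry over as a step of one size from the core of compound 1 to the core of compound 3 in this assay: the same change on two cores in this assay, an at least 3.3-fold lower number (0.52 log units; beyond the scatter) from compound 1 to compound 2 and an at least 1.1-fold higher number (0.04 log units; that floor lies within the scatter) from compound 3 to compound 4, at least 3.7-fold (0.56 log units) apart, beyond the scatter of two such steps.

Among these compounds, on the core of compound 3 the step reads an at least 1.1-fold higher number from compound 3 to compound 4 (0.04 log units; that floor lies within the scatter), and the lower number seen on the core of compound 1 has no counterpart there. From the compounds shown here alone, compound 4 gives only a limit, > 100000 nM; the true size of its step stays unknown, and the two cores differ in more than one place, so the data do not show which of those differences goes with the split in the two steps.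

Among the compounds shown here, with only one pair on each core, it remains open whether this split belongs to methylsulfanyl alone or would also appear with an amine or a longer sulfur-linked chain such as ethylsulfanyl at the same ring carbon. Going by these compounds, it also remains open whether any group at that carbon on the core of compound 3 gives a number clearly lower than that of compound 3 in this assay.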